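Difluoromethoxy in place of trifluoromethoxy on the urea aryl

This account rests on a few compounds, and the source may have more. Where it says the series, first, only, none or still open, it means among the compounds named here.

Three members of the series share one core. Compound 2 `CNc1nccc(N2CC[C@H](NC(=O)Nc3ccc(OC(F)(F)F)cc3)C2)n1` gives 98.1% in an ADME assay on a cell-free system (plasma, Rattus norvegicus) for protein binding. Compound 3 `CNc1nccc(N2CC[C@H](NC(=O)Nc3ccc(C)c(Cl)c3)C2)n1` gives 98.9%, a value that lies within the usual scatter of that of compound 2. Compound 1 `CNc1nccc(N2CC[C@H](NC(=O)Nc3ccc(CN(C)C)c(C(F)(F)F)c3)C2)n1` gives 91%, a clearly larger unbound fraction than compound 2, beyond the scatter. Compound 2 thus sits with compound 3 at the strongly bound end of the small set.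

Compound 4 `CNc1nccc(N2CC[C@H](NC(=O)Nc3ccc(OC(F)F)cc3)C2)n1` differs from compound 2 in one place: hydrogen in place of fluoro on a saturated chain carbon bound to two fluorine atoms and an oxygen on an aromatic ring. Among the measured compounds shown here, no measured pair shows this change. A step from compound 2 to compound 4 of a 1.6-fold higher unbound fraction from compound 2 to compound 4 (0.20 log units; within the scatter) in this assay is expected, slightly toward a larger unbound fraction, not clearly beyond the scatter. Compound 4 is estimated at 97%, range 93.5% to 98.6%.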

Compound 4, plasma protein binding: 97.7%
For compound 4 the middle estimate is 1.3-fold (0.12 log units) (unbound fraction) above the measured one, within the range that was stated.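

Trifluoromethoxy to difluoromethoxy gives the first step in the series that can be read at a single place: in this assay the change gives a 1.2-fold higher unbound fraction from compound 2 to compound 4 (0.08 log units; within the scatter) and stays within the scatter. Replacing one fluoro with hydrogen on this carbon therefore leaves no clear mark on the read-out, and compound 4 stays with the strongly bound compounds. Nothing available bears on why this step is so small.

Among the compounds shown here, with only one pair at this place, the reading rests on a single change. As far as these compounds go, whether a methoxy group, an amine or a carboxylic acid at this place would give a clearly larger unbound fraction remains open.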